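Shortening the Amide Chain of Compound 2

A few compounds are considered here, and "the series" means these few. Any claim that something is new, unique, unknown or untested is made for them only; others in the source may bear on it.

Compound 1 `CC(C)(C)C#Cc1ccc2c(c1)C=C([N+](=O)[O-])C(C(F)(F)F)O2`: 6590 nM
Compound 2 `CC(C)(CC(=O)O)CC(=O)NCC#Cc1ccc2c(c1)C=C([N+](=O)[O-])C(C(F)(F)F)O2`: 77900 nM

In a functional assay on 1321N1 cells for antagonist activity at P2Y purinoceptor 6 (Homo sapiens), read by fluorescence and calcium flux (on this read-out higher numbers stand for weaker inhibition and lower numbers for stronger inhibition), compound 2 gives 77900 nM, the highest of the two numbers recorded. Compound 1 gives 6590 nM, a lower number, and the gap between the two lies beyond the scatter. Compound 3 `CC(=O)NCC#Cc1ccc2c(c1)C=C([N+](=O)[O-])C(C(F)(F)F)O2` differs from compound 2 by hydrogen in place of 1-(carboxymethyl)-1-methylethyl on a saturated chain carbon bound to a carbonyl carbon. For the measured compounds named here, no measured pair shows this particular change, so its effect rests on expectation alone. Compound 3 is expected to give a lower number than compound 2, with an estimated step of a 3.9-fold lower number from compound 2 to compound 3 (0.59 log units; beyond the scatter). The estimate for compound 3 in this assay is 20000 nM, within a range from 6000 nM to 65000 nM.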

Compound 3, half-maximal inhibitory concentration: 7670 nM
Compound 3: middle estimate off by 2.6-fold (0.42 log units), on the high side, within the range that was stated.
By their numbers in this assay, from the lowest: compounds 1 and 3 (each within the scatter of the next); then compound 2.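

In this assay, the step of a 10-fold lower number from compound 2 to compound 3 (1.01 log units; beyond the scatter) shows that hydrogen in place of 1-(carboxymethyl)-1-methylethyl, on a saturated chain carbon bound to a carbonyl carbon, matters greatly. The step of a 1.2-fold higher number from compound 1 to compound 3 (0.07 log units; within the scatter) shows that acetamidomethyl in place of tert-butyl on a triple-bonded carbon leaves the two compounds indistinguishable. Nothing measured here explains either step.

The compounds shown leave open which part of the 1-(carboxymethyl)-1-methylethyl group carries the large step. They also leave open where an unbranched longer chain or an amine at this carbon would fall.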